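Halogen Swaps on an Aniline Ring: What the Third Analogue Might Do

The compounds below may be only part of what the source reports. "The series", "measured", "known", "first", "only" and "open" are said of these compounds alone.

Measured so far:
compound 1 `Cc1n[nH]c2ccc(-c3nc4cnc(N5CCN(C)CC5)cn4c3Nc3ccc(F)cc3)cc12`: 0%
compound 2 `Cc1n[nH]c2ccc(-c3nc4cnc(N5CCN(C)CC5)cn4c3Nc3ccc(I)cc3)cc12`: 0%

In a functional assay on MV4-11 cells (Homo sapiens) for inhibition, with a stated time of 120 h, tested at 10 uM (on this read-out lower numbers stand for less inhibition and higher numbers for more inhibition at the one concentration tested (going by the name of the read-out)), compound 1 gives 0%. Compound 2 gives 0% in this assay. The two share one core and differ only in the halogen on the outer ring; that single step, iodo in place of fluoro on an aromatic carbon, produced no change at the digits printed from compound 1 to compound 2 (within the scatter). Compound 2 therefore stands level with compound 1, both at the floor of the read-out, with nothing to tell them apart.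

Compound 3 `Cc1n[nH]c2ccc(-c3nc4cnc(N5CCN(C)CC5)cn4c3Nc3ccc(Br)cc3Cl)cc12` is the next variation on the same ring. Its difference from compound 2 is 4-bromo-2-chlorophenyl in place of 4-iodophenyl on a nitrogen on an aromatic ring. Going by the values given here, the one measured step that bears on this change is the halogen swap on this same ring, which did nothing. Among the compounds with values here, a second halogen on the same ring, in place of a larger one, is a modest further change, and no measured step points to a gain. For compound 3 the expected step is a number 2 percentage points higher from compound 2 to compound 3 (within the scatter), none beyond the scatter. Compound 3 is therefore estimated at 2%, with a range of 0% to 15%.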

Compound 3, a percentage reported as inhibition, at one concentration (the size of the read-out at that concentration, not a potency): 70.5%
Compound 3: middle estimate off by 68.5 percentage points, on the low side; the whole stated range lies below it.
By their numbers in this assay, from the lowest: compounds 1 and 2 (each within the scatter of the next); then compound 3.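

This position on the outer ring is not indifferent to what it carries. In this assay the swap to 4-bromo-2-chlorophenyl from 4-iodophenyl gives a number 70.5 percentage points higher from compound 2 to compound 3 (beyond the scatter) and the swap from 4-fluorophenyl gives a number 70.5 percentage points higher from compound 1 to compound 3 (beyond the scatter), so the same large step appears from both compounds with a single halogen on this ring. The earlier pair showed only that exchanging one single halogen for another left the read-out where it was, whereas this result shows that a change on the same ring, attached through the same nitrogen, can move a flat series well off zero, and no measurement available here gives a reason for that jump.

The change to compound 3 replaces iodine with bromine and adds a chlorine in one move, so the compounds shown cannot tell whether the chlorine, the bromine or the pairing of the two carries the step. Rings bearing chlorine alone or bromine alone would separate these, and a methyl or methoxy group in place of the chlorine would show whether a halogen is needed there at all.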